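Methoxy for trifluoromethyl on a phenyl of the shared core

The source may report more compounds than this note shows. Statements on the series, on what has been measured and on what is new or still open speak of the compounds shown alone.

Compound 1 `c1ccc(C2=NN(c3ccc(-c4ccccc4)nn3)C(c3ccccc3)C2)cc1`: 10000 nM
Compound 2 `FC(F)(F)c1ccc(C2CC(c3ccccc3)=NN2c2ccc(-c3ccccc3)nn2)cc1`: 10000 nM

In a functional assay on HepG2 cells (Homo sapiens) for antiproliferative activity, read by MTT assay, with a stated time of 24 h (a higher number here means a weaker inhibitor, a lower number a stronger inhibitor), compound 2 gives 10000 nM, level with compound 1 at the digits shown. Among the measured compounds shown here, the one measured step that touches this position, no change at the digits printed from compound 1 to compound 2 (within the scatter), brought no change beyond the scatter. Compound 3 `COc1ccc(C2CC(c3ccccc3)=NN2c2ccc(-c3ccccc3)nn2)cc1` differs from compound 2 by methoxy in place of trifluoromethyl on an aromatic carbon. Since swapping hydrogen for trifluoromethyl at this carbon left the read-out unchanged from compound 1 to compound 2, a further swap at the same carbon is expected to move it little, with the step of no change at the digits printed from compound 2 to compound 3 (within the scatter) estimated as none beyond the scatter. Compound 3 is therefore expected at 10000 nM, within 5000 nM to 20000 nM.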

Compound 3, half-maximal inhibitory concentration: > 100000 nM
Compound 3: no number, only a limit; the forecaster's own chance of this, stated with the estimate: 30%; at least 10-fold (1.00 log units) between middle value and limit.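

This aromatic carbon is not indifferent to what it carries, though trifluoromethyl and hydrogen had looked alike there: methoxy in place of trifluoromethyl gives an at least 10-fold higher number from compound 2 to compound 3 (1.00 log units; beyond the scatter), and methoxy in place of hydrogen gives an at least 10-fold higher number from compound 1 to compound 3 (1.00 log units; beyond the scatter). In this assay compound 3 gives > 100000 nM, which is a limit of the assay and not a number, so the full size of both steps stays unknown: the limit of > 100000 nM in this assay, at which 1 of the 3 values shown sits.

The compounds shown leave open how an amine, a hydroxyl or a longer alkoxy chain would read at this carbon. They also leave open whether any group here would give a lower number than compound 1.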